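The compounds below may be only part of what the source reports. "The series", "measured", "known", "first", "only" and "open" are said of these compounds alone.

In a physicochemical assay for solubility (a lower number here means a less soluble compound, a higher number a more soluble compound), compound 1 `CS(=O)(=O)c1ccc(-n2nc(C(F)F)c(C#N)c2-c2ccccc2)cc1` has no number to start from, as its result reads "not determined" (no result reported). Compound 4 `C[C@@H]1CN(c2c(C#N)c(C(F)F)nn2-c2ccc(S(C)(=O)=O)cc2)[C@H](C)CO1` replaces the phenyl of compound 1, on an aromatic carbon, with a six-membered non-aromatic ring with 2 hetero atoms: a group of 8 heavy atoms (6 carbon, 1 nitrogen, 1 oxygen; one six-membered non-aromatic ring with 2 hetero atoms) in place of a group of 6 heavy atoms (6 carbon; one six-membered aromatic ring of carbon only), on an aromatic carbon.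

The closest evidence comes from two related compounds. Compound 2 `CS(=O)(=O)c1ccc(-n2nc(C(F)F)c(C#N)c2-c2cc(F)cc(F)c2)nc1` gives 50 ug/mL. Compound 3 `C[C@@H]1CN(c2c(C#N)c(C(F)F)nn2-c2ccc(S(C)(=O)=O)cn2)[C@H](C)CO1` gives > 200 ug/mL, which is a limit of the assay and not an exact number.

The step of an at least 4.0-fold higher number from compound 2 to compound 3 (0.60 log units; beyond the scatter) brings in the same non-aromatic ring, in place of a six-membered aromatic ring of carbon only that carries fluorine there. Going by the values given here, it is the only measured step that bears on this change, and it lies beyond the scatter. On these data alone, its full size is unknown, since it ends at a limit. Compounds 2 and 3 also differ from compounds 1 and 4 elsewhere in the structure, so the step carries over only loosely.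

A rise of at least modest size is therefore expected in this assay for this swap. Compound 4 could also be reported only as a limit, given (the limit of > 200 ug/mL in this assay, at which 1 of the 3 values shown sits). The expected value for compound 4 is 150 ug/mL, with an estimated range from 50 ug/mL to 400 ug/mL.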

Compound 4, solubility: 50 ug/mL
Beside the measured number, compound 4's estimate is 3.0-fold (0.48 log units) above it; the range from low to high includes it.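

In this assay, going by these compounds alone, compound 1 reads "not determined" (no result reported), so no step from compound 1 to compound 4 can be read from this result. The compounds shown leave open how far the swap from phenyl to the six-membered non-aromatic ring moves the number in this assay on the core of compound 1.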